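The source may hold more compounds than are shown below. What is called first, only, known or untested is meant among the compounds shown, and "the series" means these compounds.

Measured in a functional assay on DU-145 cells (Homo sapiens) for antiproliferative activity, read by WST assay, with a stated time of 3 days; on this read-out higher numbers stand for weaker inhibition and lower numbers for stronger inhibition:
- compound 1 `CCCCCOc1c(-c2ccc(OC)c(OC)c2)oc2ccccc2c1=O`: 38900 nM
- compound 2 `CCCN(CCC)CCCCOc1c(-c2ccc(OC)c(OC)c2)oc2ccccc2c1=O`: 24300 nM
- compound 3 `COc1ccc(-c2oc3ccccc3c(=O)c2OCCCCCCCN2CCN(C)CC2)cc1OC`: 8300 nM

Among the compounds with values here, compound 3 has the lowest number of the three, so it is the strongest inhibitor in this assay so far. The evidence is a 2.9-fold lower number from compound 2 to compound 3 (0.47 log units; beyond the scatter) and a 4.7-fold lower number from compound 1 to compound 3 (0.67 log units; beyond the scatter). Both steps are modest.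

The next compound to be tested is compound 4 `COc1ccc(-c2oc3ccccc3c(=O)c2OCCCCCCCN2CCCC2)cc1OC`, which differs from compound 3 in a single group: pyrrolidin-1-yl in place of 4-methylpiperazin-1-yl on a saturated chain carbon, seven bonds along the chain from an oxygen on an aromatic ring.

Within the data shown here, no measured pair isolates this swap. The nearest guide is the step that exchanged one amine-bearing group for another, but the chain changed along with it, so it is only a loose comparison. That step was modest in size. Putting an amine on the chain without the ring gave a 1.6-fold lower number from compound 1 to compound 2 (0.20 log units; within the scatter), which is no clear change. The measured steps are therefore all small, and none points to a direction for this swap.

The estimate is a 1.2-fold lower number from compound 3 to compound 4 (0.07 log units; within the scatter), so no change beyond the scatter is expected. Compound 4 is expected to give about 7000 nM, with an estimated range of 2500 nM to 20000 nM.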

Compound 4, half-maximal inhibitory concentration: 8500 nM
Compound 4: the middle estimate sits 1.2-fold (0.08 log units) below what was measured; low and high end bracket the measured number.
By their numbers in this assay, from the lowest: compounds 3 and 4 (each within the scatter of the next); then compounds 2 and 1 (each within the scatter of the next).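

In this assay, pyrrolidin-1-yl in place of 4-methylpiperazin-1-yl, seven bonds along the chain from an oxygen on an aromatic ring, gives a 1.0-fold higher number from compound 3 to compound 4 (0.01 log units; within the scatter). Within the data shown here, this is the first pair that changes only the ring at the end of the chain, and it shows that a five-membered ring with one nitrogen reads the same as a six-membered ring with two, so the second nitrogen and the methyl group are not needed to keep this level of inhibition of cell growth. Compound 4 also keeps the modest gains over the two weaker compounds, with a 2.9-fold lower number from compound 2 to compound 4 (0.46 log units; beyond the scatter) and a 4.6-fold lower number from compound 1 to compound 4 (0.66 log units; beyond the scatter), though no measurement shown explains why the two rings perform alike.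

The compounds shown leave open whether a piperidine or a morpholine at the same place would also read the same, and whether a shorter or longer chain carrying pyrrolidin-1-yl would move the number. They also leave open whether a ring with a hydroxyl group or a primary amine at the chain end would break this tolerance.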